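Compound 2 to compound 3: bromo for methoxy

The source may report more compounds than this note shows. Statements on the series, on what has been measured and on what is new or still open speak of the compounds shown alone.

For the measured compounds named here, in a functional assay on A549 cells (Homo sapiens) for antiproliferative activity, read by MTT assay, with a stated time of 48 h (a lower number here means a stronger inhibitor, a higher number a weaker inhibitor), compound 2 (`COc1ccc(-c2nnc(NC(=O)/C=C/c3ccccc3)s2)cc1`) gives 0.68 ug/mL and holds the lowest of the two numbers so far, while compound 1 (`Cc1ccc(-c2nnc(NC(=O)/C=C/c3ccccc3)s2)cc1`) gives 1.38 ug/mL as its nearest neighbour. Compound 3 (`O=C(/C=C/c1ccccc1)Nc1nnc(-c2ccc(Br)cc2)s1`) carries bromo in place of methoxy on an aromatic carbon. Going by the values given here, the only measured step at this place is a 2.0-fold lower number from compound 1 to compound 2 (0.31 log units; beyond the scatter) and it is modest. Among the compounds with values here, no bromo compound has been measured yet, so a similarly modest move to a higher number is expected in this assay. The estimated change is a 1.8-fold higher number from compound 2 to compound 3 (0.25 log units; within the scatter) and no larger move is expected. The estimate for compound 3 is 1.2 ug/mL (expected range 0.45 ug/mL to 3.2 ug/mL).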

Compound 3, half-maximal inhibitory concentration: 2.18 ug/mL
Compound 3: the middle estimate sits 1.8-fold (0.26 log units) below what was measured; the measured number falls inside the stated range.
By their numbers in this assay, from the lowest: compound 2; then compounds 1 and 3 (each within the scatter of the next).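

In this assay the change from 4-methoxyphenyl to 4-bromophenyl moves to a higher number (a 3.2-fold higher number from compound 2 to compound 3 (0.51 log units; beyond the scatter)) so the lower number of compound 2 does not carry over to bromo. Bromo and methyl on this aromatic carbon are not separated (a 1.6-fold higher number from compound 1 to compound 3 (0.20 log units; within the scatter)) and, of the three groups, only methoxy stands apart. No measured evidence here accounts for this difference.

Still open, going by these compounds, is whether an amine or a hydroxyl on this carbon would match methoxy, and whether a longer chain such as ethoxy would keep its lower number.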